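Aryl swap at the imine carbon: hydroxyphenyl analogue

The compounds below may be only part of what the source reports. "The series", "measured", "known", "first", "only" and "open" are said of these compounds alone.

Going by the values given here, compound 1 `Cc1c(/N=C/c2ccccc2Cl)c(=O)n(-c2ccccc2)n1C` stands second highest of the three numbers so far in a functional assay on HCT-116 cells (Homo sapiens) for cytotoxicity, read by MTT assay, with a stated time of 72 h (a higher number here means a weaker inhibitor, a lower number a stronger inhibitor), where compound 1 gives 851000000 nM. Compound 2 `COc1cccc(/C=N/c2c(C)n(C)n(-c3ccccc3)c2=O)c1` gives 933000000 nM in this assay, and compound 3 `Cc1c(/N=C/c2cccc([N+](=O)[O-])c2)c(=O)n(-c2ccccc2)n1C` gives 363000000 nM. The step of a 1.1-fold higher number from compound 1 to compound 2 (0.04 log units; within the scatter) was an aryl swap at the same place; the step of a 2.6-fold lower number from compound 2 to compound 3 (0.41 log units; beyond the scatter) changed a substituent on the aryl ring. Compound 4 `Cc1c(/N=C/c2ccc(O)cc2)c(=O)n(-c2ccccc2)n1C` differs from compound 1 by 4-hydroxyphenyl in place of 2-chlorophenyl on a carbon with a double bond to nitrogen. The aryl-swap step from compound 1 to compound 2 was within the scatter, so no step beyond the scatter is expected here, and the change from compound 1 to compound 4 is estimated as a 1.1-fold lower number from compound 1 to compound 4 (0.03 log units; within the scatter). For compound 4 in this assay the expected value is 800000000 nM, with a range from 300000000 nM to 2000000000 nM.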

Compound 4, half-maximal inhibitory concentration: 646000000 nM
For compound 4 the middle estimate is 1.2-fold (0.09 log units) above the measured one; the range from low to high includes it.
By their numbers in this assay, from the lowest: compounds 3, 4, 1 and 2 (each within the scatter of the next, the first and the last beyond it).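

In this assay the steps of a 1.3-fold lower number from compound 1 to compound 4 (0.12 log units; within the scatter) and a 1.4-fold lower number from compound 2 to compound 4 (0.16 log units; within the scatter) show that 4-hydroxyphenyl on the carbon with a double bond to nitrogen stays within the scatter of both the 2-chlorophenyl and the 3-methoxyphenyl analogues. Unlike 2-chlorophenyl, the entering group carries a hydrogen-bond donor, and this swap produces no step beyond the scatter. No available evidence bears on this result.

On these data alone, whether an amine or a carboxylic acid on the aryl ring would move the number beyond the scatter remains open. So does the effect of a longer chain in place of the aryl ring at this carbon.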